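Benzyl group exchange on the shared core: compound 3 ahead

The source may report more compounds than this note shows. Statements on the series, on what has been measured and on what is new or still open speak of the compounds shown alone.

Values so far in a functional assay on KB cells (Homo sapiens) for antiproliferative activity, read by sulforhodamine B assay, with a stated time of 72 h; a higher number here means a weaker inhibitor, a lower number a stronger inhibitor:
- compound 1 `N#Cc1cccc(Cn2cc(CNC3=C(Cl)C(=O)c4cccnc4C3=O)nn2)c1` gives 5010 nM
- compound 2 `Cc1ccc(Cn2cc(CNC3=C(Cl)C(=O)c4cccnc4C3=O)nn2)cc1` gives 5050 nM

Going by the values given here, compound 2 stands level with compound 1, the only other measured member of the series, and the two values lie within the scatter of each other. The next compound is compound 3 `N#Cc1ccccc1Cn1cc(CNC2=C(Cl)C(=O)c3cccnc3C2=O)nn1`, which departs from compound 2 by one change: 2-cyanophenyl in place of 4-methylphenyl on a saturated chain carbon bound to an aromatic nitrogen. In words, 2-cyanophenyl stands in place of 4-methylphenyl on a saturated chain carbon bound to an aromatic nitrogen. Among the compounds with values here, one measured step bears on this place: a 1.0-fold higher number from compound 1 to compound 2 (0.00 log units; within the scatter), with 4-methylphenyl in place of 3-cyanophenyl. Within the data shown here, that single step is small, and no measurement yet covers 2-cyanophenyl, so the expectation rests on little. The expected step is a 1.0-fold lower number from compound 2 to compound 3 (0.00 log units; within the scatter) in this assay, with no direction and nothing beyond the scatter expected. The estimate for compound 3 is 5000 nM as a middle value, with an expected range from 2200 nM to 11000 nM in this series.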

Compound 3, half-maximal inhibitory concentration: 5130 nM
Compound 3: the middle estimate sits 1.0-fold (0.01 log units) below what was measured; measured number inside the range.
By their numbers in this assay, from the lowest: compounds 1, 2 and 3 (each within the scatter of the next).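

In this assay, 2-cyanophenyl on the saturated chain carbon bound to an aromatic nitrogen reads the same as 4-methylphenyl within the scatter (a 1.0-fold higher number from compound 2 to compound 3 (0.01 log units; within the scatter)), so this exchange of 4-methylbenzyl for 2-cyanobenzyl, which adds a nitrile and one hydrogen-bond acceptor, gives no measurable separation. The series now also holds a pair that differs only in where the nitrile stands on the benzyl group, and 2-cyanophenyl in place of 3-cyanophenyl also stays within the scatter (a 1.0-fold higher number from compound 1 to compound 3 (0.01 log units; within the scatter)). For compounds 1, 2 and 3, then, the position tolerates all three of these substituted benzyl groups without a readable difference, and no measurement available here accounts for that sameness.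

What the three compounds leave open is whether anything at this position can move the value beyond the scatter, since they cover only methyl and nitrile substituents on a benzyl group. A carboxylic acid or an aminomethyl group on the phenyl ring, or a longer chain in place of the single saturated carbon, would test the position more widely.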